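From thiophen-2-yl to 3-fluoropyridin-2-yl: a stability estimate

The compounds below may be only part of what the source reports. "The series", "measured", "known", "first", "only" and "open" are said of these compounds alone.

Of the compounds shown here, three have so far been measured in an ADME assay on S9 fraction from liver (Homo sapiens) for metabolic stability, read by LC-MS, using NADPH, with a stated time of 90 min, tested at 5 uM; on this read-out higher numbers stand for a more stable compound and lower numbers for a less stable compound. Compound 1 (`O=C(NO)c1cc(F)c(Cn2nnc(-c3ccco3)n2)c(F)c1`) gives 94%. Compound 2 (`Cn1c(Sc2c(F)cc(C(=O)NO)cc2F)nnc1-c1cccs1`) gives 83%, and compound 3 (`O=C(NO)c1cc(F)c(Cc2nnc(-c3ccncc3)s2)c(F)c1`) gives 68%. Compound 2 is therefore the second highest of the three, lying below compound 1 and above compound 3, with both gaps beyond the usual scatter.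

Compound 4 (`Cn1c(Sc2c(F)cc(C(=O)NO)cc2F)nnc1-c1ncccc1F`) has not yet been measured. It differs from compound 2 in one place: 3-fluoropyridin-2-yl in place of thiophen-2-yl on an aromatic carbon. In words, 3-fluoropyridin-2-yl stands in place of thiophen-2-yl on an aromatic carbon. Among the compounds with values here, no two measured compounds differ in just one place, so the data offer no direct precedent for this swap.

With so little to go on, the expectation is a small downward shift that stays within the scatter. The estimated change is a number 3 percentage points lower from compound 2 to compound 4 (within the scatter). The range should stay wide, as compound 3 at 68% shows how far a compound in this small set can lie from compound 2. For compound 4 the estimated value is 80%, with an expected range from 64% to 95%.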

Compound 4, percent of the compound remaining: 80%
Compound 4: the middle estimate sits on the measured number at the digits printed; the measured number falls inside the stated range.
By their numbers in this assay, from the lowest: compound 3; then compounds 4 and 2 (each within the scatter of the next); then compound 1.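

In this assay, within the data shown here, the swap of thiophen-2-yl for 3-fluoropyridin-2-yl gives a number 3 percentage points lower from compound 2 to compound 4 (within the scatter), the first comparison in this set between compounds that differ in only one place. On this aromatic carbon between two ring nitrogen atoms, a five-membered aromatic ring can therefore give way to a larger six-membered one carrying fluorine, and the read-out cannot tell compound 2 and compound 4 apart. Nothing available explains this result.

On these data alone, both groups seen at this position are uncharged aromatic rings, so it remains open what an amine or a carboxylic acid placed there would do to the stability number. As far as these compounds go, it is also open whether the same swap would give a similar result on the core of compound 1 or compound 3.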